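Notes: benzamido on the double-bonded nitrogen

A few compounds are considered here, and "the series" means these few. Any claim that something is new, unique, unknown or untested is made for them only; others in the source may bear on it.

Measured in a functional assay on MCF7 cells (Homo sapiens) for cytotoxicity, read by sulforhodamine B assay, with a stated time of 24 h; a higher number here means a weaker inhibitor, a lower number a stronger inhibitor:
- compound 1 `O=C1Nc2ccc(S(=O)(=O)N3CCOCC3)cc2/C1=N/c1ccc(Br)cc1`: 44800 nM
- compound 2 `Cc1ccc(/N=C2\C(=O)Nc3ccc(S(=O)(=O)N4CCOCC4)cc32)cc1`: 55900 nM
- compound 3 `N/N=C1\C(=O)Nc2ccc(S(=O)(=O)N3CCOCC3)cc21`: 46800 nM

Compound 2 stands level with the other two measured compounds within the scatter. Compound 4 `O=C1Nc2ccc(S(=O)(=O)N3CCOCC3)cc2/C1=N/NC(=O)c1ccccc1` is the next case, with benzamido in place of 4-methylphenyl on a double-bonded nitrogen. Two measured exchanges on that nitrogen bear on it, a 1.2-fold lower number from compound 2 to compound 3 (0.08 log units; within the scatter) and a 1.0-fold higher number from compound 1 to compound 3 (0.02 log units; within the scatter). Both lie within the scatter, as does a 1.2-fold higher number from compound 1 to compound 2 (0.10 log units; within the scatter) on an aromatic carbon. Benzamido itself has not been measured in this series, so the range stays wide. No change beyond the scatter is expected, and the expected 1.2-fold lower number from compound 2 to compound 4 (0.09 log units; within the scatter) is correspondingly small. For compound 4 the estimate is 45000 nM, with an expected range of 20000 nM to 90000 nM.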

Compound 4, half-maximal inhibitory concentration: 414000 nM
Beside the measured number, compound 4's estimate is 9.2-fold (0.96 log units) below it, and the stated range ends below it.
By their numbers in this assay, from the lowest: compounds 1, 3 and 2 (each within the scatter of the next); then compound 4.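

In this assay, exchanges on the double-bonded nitrogen had stayed within the scatter, but benzamido gives a 7.4-fold higher number from compound 2 to compound 4 (0.87 log units; beyond the scatter) and a 9.2-fold higher number from compound 1 to compound 4 (0.97 log units; beyond the scatter), so this position does respond to the group placed there. Benzoyl in place of hydrogen on the amine nitrogen gives an 8.8-fold higher number from compound 3 to compound 4 (0.95 log units; beyond the scatter), the same direction from the unsubstituted amine. Nothing available accounts for this shift.

On these data alone, whether the shift follows the carbonyl or the phenyl ring of benzamido remains open. Acetyl on the amine nitrogen would test whether a smaller acyl group behaves like benzoyl.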